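This account rests on a few compounds, and the source may have more. Where it says the series, first, only, none or still open, it means among the compounds named here.

For the measured compounds named here, compound 2 `O=[N+]([O-])c1cccc(S(=O)(=O)c2nc(-c3cnn4ccc(Br)cc34)cs2)c1` is the only compound in this set for which a number is reported: in an assay on isolated protein for inhibition of phosphatidylinositol 4,5-bisphosphate 3-kinase catalytic subunit beta isoform (Homo sapiens) (on this read-out lower numbers stand for stronger inhibition and higher numbers for weaker inhibition), compound 2 gives 5450 nM. Compound 1 `Cc1ccc([N+](=O)[O-])cc1S(=O)(=O)N[C@@H]1CCCN(Cc2cnn3ccc(C#N)cc23)C1` is reported in this assay only as a limit, > 1000 nM, and not as a number. The whole set therefore rests on one number and (the limit of > 1000 nM in this assay, at which 1 of the 2 values shown sits). Compound 3 `N#Cc1ccc(F)c(S(=O)(=O)c2nc(-c3cnn4ccc(Br)cc34)cs2)c1` has not yet been measured, and it differs from compound 2 in one place: 5-cyano-2-fluorophenyl in place of 3-nitrophenyl on a sulfonyl sulfur. Going by the values given here, no step between two measured compounds is available here, so the size of this change cannot be read from a measured pair. The expected step is a 1.4-fold lower number from compound 2 to compound 3 (0.13 log units; within the scatter), a change not beyond the usual scatter in either direction. On that basis compound 3 is estimated at 4000 nM in this assay, with a plausible range from 1000 nM to 16000 nM.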

Compound 3, half-maximal inhibitory concentration: > 1000 nM
Compound 3 was reported as a limit; the forecaster's own chance of this, stated with the estimate: 20%; the middle value is on the limit's open side.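

For the compounds shown here, no step from compound 2 to compound 3 can be read, because compound 3 is reported only as a limit: the limit of > 1000 nM in this assay, at which 2 of the 3 values shown sit. The compounds shown leave open whether 5-cyano-2-fluorophenyl in place of 3-nitrophenyl on a sulfonyl sulfur changes the number in this assay, and in which direction.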